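Benzimidazole series: styryl in place of phenoxy on compound 1

The compounds below may be only part of what the source reports. "The series", "measured", "known", "first", "only" and "open" are said of these compounds alone.

Measured compounds:
compound 1 `Clc1ccc2[nH]c(SCc3ccccc3Oc3ccccc3)nc2c1`: 30%
compound 2 `c1ccc(CCc2ccccc2CSc2nccs2)cc1`: 31%
compound 3 `c1ccc(CCc2ccccc2CSC2=NCCN2)cc1`: 17%

In an assay on isolated protein for inhibition of Indoleamine 2,3-dioxygenase 1 (Homo sapiens), with a stated time of 60 min, tested at 10 uM (on this read-out lower numbers stand for less inhibition and higher numbers for more inhibition at the one concentration tested (going by the name of the read-out)), compound 1 gives 30%, the second highest of the three numbers. Compound 2 gives 31%, which is within the scatter of compound 1. Compound 3 gives 17%, the lowest number of the three and beyond the scatter from compound 1. Within the data shown here, the one step measured between compounds differing in a single place is a number 14 percentage points lower from compound 2 to compound 3 (beyond the scatter), a change on a sulfur of the shared side chain, not on the aromatic ring.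

Compound 4 `Clc1ccc2[nH]c(SCc3ccccc3/C=C/c3ccccc3)nc2c1` is not yet measured. Relative to compound 1 the change is 2-phenylethenyl in place of phenoxy on an aromatic carbon. Among the measured compounds shown here, no measured step touches this position; the step from compound 2 to compound 3 concerns a different part of the molecule, so it does not bear on the exchange. Compound 1 and compound 2 both sit near the same number despite different cores, which suggests the read-out is not very sensitive to these peripheral changes. The expected step is therefore none beyond the scatter: no change at the digits printed from compound 1 to compound 4 (within the scatter). Compound 4 is estimated at 30%, with a range from 15% to 50%.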

Compound 4, a percentage reported as inhibition, at one concentration (the size of the read-out at that concentration, not a potency): -6%
Compound 4: the middle estimate sits 36 percentage points above what was measured, outside the stated range (below it).
By their numbers in this assay, from the lowest: compound 4; then compound 3; then compounds 1 and 2 (each within the scatter of the next).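

Exchanging phenoxy for 2-phenylethenyl on the aromatic carbon, ortho to a large group, gives a number 36 percentage points lower from compound 1 to compound 4 (beyond the scatter) in this assay, so this position is far from indifferent to the group it carries. Among these compounds, compound 4 gives -6%, which shows no inhibition at the one concentration tested, whereas the only earlier step, a number 14 percentage points lower from compound 2 to compound 3 (beyond the scatter), lay on a sulfur and said nothing about this position. No available evidence accounts for the loss on this exchange.

The exchange alters the link to the outer phenyl ring and the heavy-atom count together, so these compounds cannot show whether losing the oxygen or gaining the double bond matters more. Also open, going by these compounds, is how this position would read with an anilino group, with its amine link, or a benzyloxy group in place of phenoxy, and whether a carboxylic acid on the outer phenyl ring would change the number for either compound 1 or compound 4.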